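The compounds below may be only part of what the source reports. "The series", "measured", "known", "first", "only" and "open" are said of these compounds alone.

Among the compounds with values here, in a functional assay on K562 cells (Homo sapiens) for antiproliferative activity, read by sulforhodamine B assay, with a stated time of 72 h (a higher number here means a weaker inhibitor, a lower number a stronger inhibitor), three compounds that differ only in the ring on a sulfonamide nitrogen have numbers so far. Compound 1 `Cc1cc(C)nc(NS(=O)(=O)c2ccc(Nc3nncc4ccccc34)cc2)n1`, carrying 4,6-dimethylpyrimidin-2-yl, gives 4.9 nM and is the strongest of them. Compound 2 `O=S(=O)(Nc1ncccn1)c1ccc(Nc2nncc3ccccc23)cc1` gives 43 nM, and compound 3 `O=S(=O)(Nc1nccs1)c1ccc(Nc2nncc3ccccc23)cc1` gives 54 nM. Compound 3 therefore belongs with compound 2 at the weak end of this small set. The measured steps show a 1.3-fold higher number from compound 2 to compound 3 (0.10 log units; within the scatter), which is within the scatter, but an 11-fold higher number from compound 1 to compound 3 (1.04 log units; beyond the scatter), which is large.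

Compound 4 `O=S(=O)(Nc1ccccn1)c1ccc(Nc2nncc3ccccc23)cc1` has pyridin-2-yl in place of 1,3-thiazol-2-yl on a sulfonamide nitrogen. Within the data shown here, the closest precedent is the exchange of one unsubstituted ring for another, seen in a 1.3-fold higher number from compound 2 to compound 3 (0.10 log units; within the scatter). The larger 8.8-fold higher number from compound 1 to compound 2 (0.94 log units; beyond the scatter) involves leaving the 4,6-dimethylpyrimidin-2-yl, which plays no part in this change. No step beyond the scatter is therefore expected, in either direction. The estimate amounts to a 1.1-fold lower number from compound 3 to compound 4 (0.03 log units; within the scatter), an expected step of little size. For compound 4, the expected value is 50 nM, with an estimated range of 17 nM to 150 nM.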

Compound 4, half-maximal inhibitory concentration: 34 nM
For compound 4 the middle estimate is 1.5-fold (0.17 log units) above the measured one; low and high end bracket the measured number.
By their numbers in this assay, from the lowest: compound 1; then compounds 4, 2 and 3 (each within the scatter of the next).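

In this assay, swapping the five-membered 1,3-thiazol-2-yl for the six-membered pyridin-2-yl gives no step beyond the scatter (a 1.6-fold lower number from compound 3 to compound 4 (0.20 log units; within the scatter)), and neither does the exchange of pyrimidin-2-yl for pyridin-2-yl (a 1.3-fold lower number from compound 2 to compound 4 (0.10 log units; within the scatter)). All three unsubstituted rings on the sulfonamide nitrogen now lie within the scatter of one another, so in this small set neither ring size nor the change in ring atoms shifts the number measurably, while the 4,6-dimethylpyrimidin-2-yl of compound 1 remains apart (a 6.9-fold higher number from compound 1 to compound 4 (0.84 log units; beyond the scatter)). No measurement here offers a reason for this pattern.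

As far as these compounds go, it remains open whether a single methyl group on the pyrimidin-2-yl would match the two in compound 1. Also open, from the compounds shown here alone, is whether methoxy or amino groups there, or methyl groups on pyridin-2-yl, would do the same.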